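A few compounds are considered here, and "the series" means these few. Any claim that something is new, unique, unknown or untested is made for them only; others in the source may bear on it.

In a functional assay on DU-145 cells (Homo sapiens) for cytotoxicity, read by MTT assay (on this read-out higher numbers stand for weaker inhibition and lower numbers for stronger inhibition), compound 1 `CC(C)=CC[C@@H](OC(=O)c1ccco1)C1=CC(=O)c2c(O)ccc(O)c2C1=O` gives > 100000 nM, a limit and not a number. Compound 2 `COC(C)CO[C@H](CC=C(C)C)C1=CC(=O)c2c(O)ccc(O)c2C1=O` gives 16600 nM and compound 3 `CC(C)=CC[C@@H](OCC(C)O)C1=CC(=O)c2c(O)ccc(O)c2C1=O` gives 16100 nM, so compound 3 sits level with compound 2, within the scatter. Compound 4 `CC(=O)OC(C)CO[C@H](CC=C(C)C)C1=CC(=O)c2c(O)ccc(O)c2C1=O` carries acetyl in place of hydrogen on an oxygen on a saturated carbon, 2-hydroxypropyl to 2-acetoxypropyl: acetyl in place of hydrogen on an oxygen on a saturated carbon. Among the measured compounds shown here, the closest precedent is the methyl cap on that oxygen, where a 1.0-fold lower number from compound 2 to compound 3 (0.01 log units; within the scatter) lies within the scatter. The larger steps of an at least 6.0-fold lower number from compound 1 to compound 2 (0.77 log units; beyond the scatter) and an at least 6.2-fold lower number from compound 1 to compound 3 (0.79 log units; beyond the scatter) replace a whole (furan-2-yl)carbonyl group, so they bear only weakly, though they leave some risk of a higher number. The expected result is no change beyond the scatter, a 1.0-fold lower number from compound 3 to compound 4 (0.00 log units; within the scatter). For compound 4 the estimate is 16000 nM, with an expected range of 6000 nM to 45000 nM.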

Compound 4, half-maximal inhibitory concentration: 16600 nM
For compound 4 the middle estimate is 1.0-fold (0.02 log units) below the measured one; low and high end bracket the measured number.
By their numbers in this assay, from the lowest: compounds 3, 2 and 4 (each within the scatter of the next). At a limit, above all of these: compound 1.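

In this assay, acetyl on this oxygen on a saturated carbon reads the same as hydrogen or methyl there, with a 1.0-fold higher number from compound 3 to compound 4 (0.01 log units; within the scatter) and no change at the digits printed from compound 2 to compound 4 (within the scatter), so all three caps sit level. The gap to the (furan-2-yl)carbonyl compound holds with 2-acetoxypropyl too: an at least 6.0-fold lower number from compound 1 to compound 4 (0.77 log units; beyond the scatter). Compound 1 stands at a limit and not at a number, so that gap is only a bound: the limit of > 100000 nM in this assay, at which 1 of the 4 values shown sits.

Still open, as far as these compounds go, is how an amine or a carboxylic acid on this chain would read. From the compounds shown here alone, a longer chain in place of 2-acetoxypropyl is equally open.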